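The source may hold more compounds than are shown below. What is called first, only, known or untested is meant among the compounds shown, and "the series" means these compounds.

Measured in a functional assay on A549 cells (Homo sapiens) for antiproliferative activity, read by MTT assay, with a stated time of 72 h; on this read-out higher numbers stand for weaker inhibition and lower numbers for stronger inhibition:

Compound 1 `O=C(Nc1ccc(Oc2ccnc3[nH]ccc23)cc1)c1cc2cccnc2n(-c2ccccc2)c1=O` — 360 nM
Compound 2 `O=C(Nc1ccc(Oc2ccnc3[nH]ccc23)cc1)c1cc2cccnc2n(-c2ccc(F)cc2)c1=O` — 210 nM
Compound 3 `O=C(Nc1ccc(Oc2ccnc3[nH]ccc23)cc1)c1cc2cccnc2n(-c2ccc(Br)cc2)c1=O` — 280 nM

Compound 1 gives the highest of the three numbers, yet both of its steps to the others, a 1.7-fold lower number from compound 1 to compound 2 (0.23 log units; within the scatter) and a 1.3-fold lower number from compound 1 to compound 3 (0.11 log units; within the scatter), stay within the scatter, so the three compounds stand together rather than in any order. The step between the two halogenated analogues, a 1.3-fold higher number from compound 2 to compound 3 (0.12 log units; within the scatter), is equally small.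

Compound 4 `O=C(Nc1ccc(Oc2ccnc3[nH]ccc23)c(F)c1)c1cc2cccnc2n(-c2ccccc2)c1=O` differs from compound 1 by fluoro in place of hydrogen on an aromatic carbon. Going by the values given here, the only measured steps of the same kind, hydrogen to fluoro and hydrogen to bromo, sit on the phenyl attached to the core nitrogen, a different ring from the one changed in compound 4, and neither of them moved this assay beyond the scatter. Among the compounds with values here, no measured step touches the ring that carries the new fluoro in compound 4. On that basis the expected step of a 1.2-fold lower number from compound 1 to compound 4 (0.08 log units; within the scatter) is none beyond the scatter, with the range widened to cover the untested position.

For compound 4 the expected value in this assay is 300 nM, with a range from 110 nM to 850 nM.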

Compound 4, half-maximal inhibitory concentration: 190 nM
Compound 4: middle estimate off by 1.6-fold (0.20 log units), on the high side; low and high end bracket the measured number.
By their numbers in this assay, from the lowest: compounds 4, 2, 3 and 1 (each within the scatter of the next).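

Going by these compounds alone, compound 4 is the first probe of the ring that carries the amide nitrogen and the ether oxygen: fluoro sits here on an aromatic carbon, ortho to a large group and meta to a large group, and in this assay this gives a 1.9-fold lower number from compound 1 to compound 4 (0.28 log units; within the scatter). The same exchange on the phenyl attached to the core nitrogen gives a 1.7-fold lower number from compound 1 to compound 2 (0.23 log units; within the scatter), so on the compounds shown, fluoro in place of hydrogen stays within the scatter on both rings, and compound 4 stands with compounds 1, 2 and 3 rather than apart from them. Nothing at hand explains the size of this step or says whether fluoro does anything at this carbon beyond being accommodated.

Still open, from the compounds shown here alone, is whether this carbon accepts more than a single fluorine atom: a chloro, a methoxy, an amine or a carboxylic acid here could leave the number within the scatter or move it beyond. Also open, going by these compounds, is whether fluoro on both aromatic rings in one compound, the pairing of the changes in compound 2 and compound 4, would give a step that clears the scatter.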